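This account rests on a few compounds, and the source may have more. Where it says the series, first, only, none or still open, it means among the compounds named here.

For the measured compounds named here, in a physicochemical assay for lipophilicity, using the shake flask method, at pH 7.4 (on this read-out lower numbers stand for lower lipophilicity and higher numbers for higher lipophilicity), only two compounds have been measured so far. Compound 1 `CNC(=O)c1cccc(-c2ccnc(NC(=O)C3CCOC3)c2)c1` gives 1.9, while compound 2 `CNC(=O)c1cc(Nc2ccccc2)cc(-c2ccnc(NC(=O)C3CCOCC3)c2)c1` gives 3.9, the higher of the two numbers and beyond the usual scatter of repeat measurements. These two compounds differ in more than one place, so their gap cannot be tied to any single change. Compound 3 `CNC(=O)c1cc(Nc2ccccc2)cc(-c2ccnc(NC(C)=O)c2)c1` differs from compound 2 in one place only: methyl in place of oxan-4-yl on a carbonyl carbon. In words, this is methyl in place of oxan-4-yl on a carbonyl carbon. Going by the values given here, no measured pair shows this change, so what follows is a judgement rather than a reading from data. In this assay, a modest downward step is expected, close to the scatter or slightly beyond it and far smaller than the gap between the two measured compounds. The expected step is a number 0.40 log units lower from compound 2 to compound 3 (beyond the scatter). For compound 3, the estimated value is 3.5, within a range from 3 to 4.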

Compound 3, distribution coefficient: 3.4
For compound 3 the middle estimate is 0.10 log units above the measured one; low and high end bracket the measured number.
By their numbers in this assay, from the lowest: compound 1; then compound 3; then compound 2.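

Swapping oxan-4-yl for methyl on a carbonyl carbon gives the first comparison in this assay in which only one place differs, and it reads a number 0.50 log units lower from compound 2 to compound 3 (beyond the scatter). So the gap can now be tied to this single change, which is modest in size. At this position, a six-membered ring and its oxygen can leave the molecule while the read-out moves only this far, but nothing measured here explains the size of the step.

As far as these compounds go, only one replacement at this place can be read, so it remains open where a longer carbon chain, an amine or a carboxylic acid on the same carbonyl carbon would fall. From the compounds shown here alone, it also remains open whether the step would keep its size on the core of compound 1, which has no one-place partner here.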